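This account rests on a few compounds, and the source may have more. Where it says the series, first, only, none or still open, it means among the compounds named here.

Compound 2 `O=C(OC[C@H]1CN(c2ccc(-n3cc(-c4ccccn4)cn3)c(F)c2)C(=O)O1)c1ccccc1` in an ADME assay on L02 cells (Homo sapiens) for cytotoxicity, read by MTT assay, with a stated time of 48 h (on this read-out lower numbers stand for stronger inhibition and higher numbers for weaker inhibition), gives > 400 ug/mL, which is a limit of the assay rather than a number. Compound 1 `O=C1O[C@@H](CN2CCC(O)CC2)CN1c1ccc(-n2cc(-c3ccccn3)cn2)c(F)c1` in this assay gives > 400 ug/mL, likewise a limit. Going by the values given here, the one measured step, a step that the two limits leave unreadable from compound 1 to compound 2, cannot be sized because of the limit of > 400 ug/mL in this assay, at which 2 of the 2 values shown sit. Compound 3 `O=C1O[C@@H](Cn2ccnc2)CN1c1ccc(-n2cc(-c3ccccn3)cn2)c(F)c1` is reached through (1H-imidazol-1-yl in place of benzoyloxy on a saturated chain carbon bound to a saturated ring carbon). Among the compounds with values here, no measured step bears on this change, so the account expects no shift beyond the usual scatter, namely a number no higher from compound 2 to compound 3 (the limit leaves the size open). Compound 3 is accordingly estimated at 400 ug/mL, with a range from 200 ug/mL to 800 ug/mL.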

Compound 3, half-maximal inhibitory concentration: 350 ug/mL
For compound 3 the middle estimate is 1.1-fold (0.06 log units) above the measured one, and the stated range covers the measured number.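

In this assay, going by these compounds alone, compound 3 gives 350 ug/mL, the only one of the three values that is a number and not a limit. At this place on a saturated chain carbon bound to a saturated ring carbon, 1H-imidazol-1-yl gives an at least 1.1-fold lower number from compound 2 to compound 3 (0.05 log units; that floor lies within the scatter) and an at least 1.1-fold lower number from compound 1 to compound 3 (0.05 log units; that floor lies within the scatter), so neither floor shows a shift beyond the scatter. The full size of both steps stays unreadable because of what bounds them: the limit of > 400 ug/mL in this assay, at which 2 of the 3 values shown sit. The compounds shown leave open whether another group at this place, such as a morpholine or a carboxylic acid, would also give a number rather than a limit.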